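A Dihydroxy Side Chain in Place of an Alkene

The source may report more compounds than this note shows. Statements on the series, on what has been measured and on what is new or still open speak of the compounds shown alone.

Measured in a functional assay on HL-60 cells (Homo sapiens) for antiproliferative activity, read by CCK-8 assay, with a stated time of 72 h; a higher number here means a weaker inhibitor, a lower number a stronger inhibitor:
- compound 1 `Cc1ccc(/C=C(\C(=O)O)C(C)C)c2c1CC[C@@H](C(C)(C)O)OC2=O`: > 100000 nM
- compound 2 `CC(=O)Oc1cc2c(CCC=C(C)C)c(C)ccc2cc1C(C)C`: 20800 nM

The entry for compound 1, > 100000 nM, is a limit of the assay and not a number. Among the compounds with values here, compound 2, at 20800 nM, therefore holds the only true number in this assay, and it can be ranked against no other measured value. Within the data shown here, no step between closely matched compounds has been measured, so the size of any structural effect remains unknown.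

Compound 3 `CC(=O)Oc1cc2c(CC[C@@H](O)C(C)(C)O)c(C)ccc2cc1C(C)C` is the next to be considered. It carries 1,2-dihydroxy-2-methylpropyl in place of 2-methylprop-1-en-1-yl on a saturated chain carbon, two bonds along the chain from an aromatic carbon.

The expectation rests only on this change and on compound 2 at 20800 nM, so it is loose. A modest weakening is expected, estimated as a 1.9-fold higher number from compound 2 to compound 3 (0.28 log units; within the scatter), and a result that reaches the limit of this assay would not be surprising. For compound 3 the estimated value is 40000 nM, with an expected range from 15000 nM to 100000 nM.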

Compound 3, half-maximal inhibitory concentration: 41200 nM
Estimate against measurement, compound 3: 1.0-fold (0.01 log units) below, and the stated range covers the measured number.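

Within the data shown here, the step of a 2.0-fold higher number from compound 2 to compound 3 (0.30 log units; within the scatter) in this assay is the first measured step, and it gives a size to the exchange of 2-methylprop-1-en-1-yl for 1,2-dihydroxy-2-methylpropyl on a saturated chain carbon, two bonds along the chain from an aromatic carbon. At this place, the two compounds cannot be told apart in this read-out, so the double bond of the outgoing group is not required for a true number to be obtained, and the two hydroxyl groups of the incoming one do not carry the value to the limit. Compound 1 alone remains at a limit, which is not a number and so offers no step: the limit of > 100000 nM in this assay, at which 1 of the 3 values shown sits.

What the compounds shown leave open is whether a single hydroxyl group, an amine or a carboxylic acid at the same place would read any differently from 1,2-dihydroxy-2-methylpropyl. Also open, from the compounds shown here alone, are the effect of a longer chain carrying the same dihydroxy end and that of the opposite configuration at the defined stereocentre of compound 3.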